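Changing the Benzyl Halogen in a Cell-Growth Assay

A few compounds are considered here, and "the series" means these few. Any claim that something is new, unique, unknown or untested is made for them only; others in the source may bear on it.

Compound 1 `Clc1ccc(COc2ccccc2/C=C/C(/C=C/c2ccccn2)=N/Oc2ncnc3cc(Cl)ccc23)cc1` was tested in a functional assay on SMMC-7721 cells (Homo sapiens) for inhibition, read by MTT assay, with a stated time of 72 h, tested at 1 uM (on this read-out higher numbers stand for a stronger effect at the one concentration tested and lower numbers for a weaker effect), where compound 1 gives 94%. In this assay compound 3 `Clc1ccccc1COc1ccccc1/C=C/C(/C=C/c1ccccn1)=N/Oc1ncnc2ccccc12` gives 95.7% and compound 2 `Cc1cccc2ncnc(O/N=C(\C=C\c3ccccn3)/C=C/c3ccccc3OCc3ccc(Cl)cc3Cl)c12` gives 90.8%. Compound 1 stands second highest of the three numbers, its nearest neighbour being compound 3 and its furthest compound 2, and all three numbers lie within the scatter of one another. Compound 4 `Fc1ccccc1COc1ccccc1/C=C/C(/C=C/c1ccccn1)=N/Oc1ncnc2cc(Cl)ccc12` differs from compound 1 in one place: 2-fluorophenyl in place of 4-chlorophenyl on a saturated chain carbon bound to an oxygen on an aromatic ring. Going by the values given here, no step between measured compounds is known, so nothing supports expecting a change beyond the scatter, and in this assay the expected step is a number 3 percentage points lower from compound 1 to compound 4 (within the scatter). Compound 4 is accordingly estimated to give 91%, with a range from 75% to 98%.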

Compound 4, a percentage reported as inhibition, at one concentration (the size of the read-out at that concentration, not a potency): 94.2%
Compound 4: middle estimate off by 3.2 percentage points, on the low side, within the range that was stated.
By their numbers in this assay, from the lowest: compounds 2, 1, 4 and 3 (each within the scatter of the next).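

Putting 2-fluorophenyl in place of 4-chlorophenyl on a saturated chain carbon bound to an oxygen on an aromatic ring gives, in this assay, a number 0.2 percentage points higher from compound 1 to compound 4 (within the scatter). Going by these compounds alone, this is the first step read between compounds differing in one place, and it shows that this place tolerates this exchange at the one concentration tested. Nothing available bears on why the step is so small.

Within the data shown here, the single step does not separate the change of halogen from the change between the 4- and 2-substituted rings. Going by these compounds, whether a benzyl group carrying an amine, or a carboxylic acid on a longer chain, would leave the read-out as it stands remains open.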